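Swapping a Phenoxy Group for a Pyrimidinylamino Group

The compounds below may be only part of what the source reports. "The series", "measured", "known", "first", "only" and "open" are said of these compounds alone.

Of the compounds shown here, three sharing one core have been measured. Compound 1 `CCSc1cc(C)c(C(=O)N=C(N)N)cc1S(C)(=O)=O` gives 5.9 nM in a functional assay for inhibition of sodium/hydrogen exchanger (Oryctolagus cuniculus); a higher number here means a weaker inhibitor, a lower number a stronger inhibitor. Compound 2 `Cc1cc(Sc2ccccc2Cl)c(S(C)(=O)=O)cc1C(=O)N=C(N)N` gives 14 nM, and compound 3 `Cc1cc(Oc2ccccc2)c(S(C)(=O)=O)cc1C(=O)N=C(N)N` gives 10 nM. Compound 3 thus holds the second highest of the three numbers, its gaps to compound 2 and to compound 1 both within the scatter. Compound 4 `Cc1cc(Nc2ncccn2)c(S(C)(=O)=O)cc1C(=O)N=C(N)N` differs from compound 3 by (pyrimidin-2-yl)amino in place of phenoxy on an aromatic carbon. Two earlier exchanges on that aromatic carbon are known: a 1.7-fold higher number from compound 1 to compound 3 (0.23 log units; within the scatter) and a 1.4-fold lower number from compound 2 to compound 3 (0.15 log units; within the scatter), neither beyond the scatter, while a 2.4-fold higher number from compound 1 to compound 2 (0.38 log units; beyond the scatter) was modest. Because a 1.7-fold higher number from compound 1 to compound 3 (0.23 log units; within the scatter) and a 1.4-fold lower number from compound 2 to compound 3 (0.15 log units; within the scatter) stayed within the scatter, the expected change is a 1.2-fold higher number from compound 3 to compound 4 (0.08 log units; within the scatter). Compound 4 is therefore estimated at 12 nM, with a range from 5 nM to 30 nM.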

Compound 4, half-maximal inhibitory concentration: 8.3 nM
Compound 4: middle estimate off by 1.4-fold (0.16 log units), on the high side; low and high end bracket the measured number.
By their numbers in this assay, from the lowest: compounds 1, 4, 3 and 2 (each within the scatter of the next, the first and the last beyond it).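

In this assay, steps of a 1.2-fold lower number from compound 3 to compound 4 (0.08 log units; within the scatter) and a 1.7-fold lower number from compound 2 to compound 4 (0.23 log units; within the scatter) and a 1.4-fold higher number from compound 1 to compound 4 (0.15 log units; within the scatter) show that (pyrimidin-2-yl)amino fits this aromatic carbon, ortho to a methylsulfonyl group, as well as the three earlier groups do. Here a linking nitrogen with a hydrogen-bond donor, and a ring holding hetero atoms, leave the number within the scatter of all the other compounds. Nothing available explains why this exchange changes so little.

On these data alone, it remains open whether a carboxylic acid or a plain amine at this carbon would also hold the number. The same goes for a longer chain.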